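An ethoxy group added to an unreadable baseline

The source may report more compounds than this note shows. Statements on the series, on what has been measured and on what is new or still open speak of the compounds shown alone.

Compound 1 `S=C(Nc1ccc(Cl)cc1)Nc1nc2ccccc2s1`: > 50000 nM (a limit)
Compound 2 `Fc1ccc(NC(=S)Nc2nc3ccccc3s2)cc1`: > 50000 nM (a limit)
Compound 3 `CCOc1ccc2nc(NC(=S)Nc3ccc(F)cc3)sc2c1`: not yet measured

Both measured compounds were tested in a functional assay on B16-F10 cells (Mus musculus) for cytotoxicity, read by MTT assay, with a stated time of 48 h; on this read-out lower numbers stand for stronger inhibition and higher numbers for weaker inhibition. Compound 2 stands only at a limit, > 50000 nM. Compound 1 also gives only a limit, > 50000 nM. The record therefore holds (the limit of > 50000 nM in this assay, at which 2 of the 2 values shown sit). Within the data shown here, the one measured step, a step that the two limits leave unreadable from compound 1 to compound 2, offers no size to build on.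

Compound 3 differs from compound 2 by ethoxy in place of hydrogen on an aromatic carbon. Among the measured compounds shown here, no measured step covers this change, so the expectation is weak, and another limit in this assay would be no surprise. The expected step, if one can be read at all, is an at least 1.2-fold lower number from compound 2 to compound 3 (0.09 log units; that floor lies within the scatter), a modest move toward stronger inhibition. Compound 3 is estimated at 40000 nM, with an expected range from 12000 nM to 90000 nM.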

Compound 3, half-maximal inhibitory concentration: > 50000 nM
Compound 3 ended at the assay's limit (the forecaster's own chance of this, stated with the estimate: 55%); middle value at least 1.2-fold (0.09 log units) away from the limit.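

The step from compound 2 to compound 3 cannot be read, as both give only a limit, and the record stays at one value: the limit of > 50000 nM in this assay, at which 3 of the 3 values shown sit.

The compounds shown leave open whether ethoxy in place of hydrogen on an aromatic carbon changes inhibition at all.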